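Swapping pyridin-3-yl for 4-fluorophenyl on compound 1

This account rests on a few compounds, and the source may have more. Where it says the series, first, only, none or still open, it means among the compounds named here.

Among the compounds with values here, of the two compounds measured so far in an ADME assay on microsomes from liver (Homo sapiens) for metabolic stability, read by LC-MS, with a stated time of 60 min, tested at 500 uM (on this read-out lower numbers stand for a less stable compound and higher numbers for a more stable compound), compound 1 `COc1cc2c(cc1OC)CN(c1cccnc1)CC2` stands lowest at 15.5%. Compound 2 `COc1cc2c(cc1OC)CN(c1cc(C(F)(F)F)cc(C(F)(F)F)c1)CC2` reaches 62.2%, a gap well beyond the usual scatter of repeat measurements. Compound 3 `COc1cc2c(cc1OC)CN(c1ccc(F)cc1)CC2` has yet to be measured. It keeps the core of compound 1 but carries 4-fluorophenyl in place of pyridin-3-yl on an amine nitrogen in a ring. Within the data shown here, no two measured compounds differ in just one place, so this change has no direct precedent here. The evidence is thin: compound 1 at 15.5% leaves much room upward, and compound 2 at 62.2% shows that far higher values occur with the shared core. A modest rise beyond the scatter is therefore expected in this assay, an estimated a number 19.5 percentage points higher from compound 1 to compound 3 (beyond the scatter). For compound 3 the estimated value is 35%, with an expected range from 15% to 58%.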

Compound 3, percent of the compound remaining: 56.9%
The estimate for compound 3 lay 21.9 percentage points below the measured number, within the range that was stated.
By their numbers in this assay, from the lowest: compound 1; then compounds 3 and 2 (each within the scatter of the next).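

In this assay, the group on the amine nitrogen in a ring clearly matters: with the rest of compound 1 unchanged, 4-fluorophenyl in place of pyridin-3-yl gives a number 41.4 percentage points higher from compound 1 to compound 3 (beyond the scatter) as a single, large step. Within the data shown here, this is the first comparison here in which only one place differs, so this shift can be tied to that position alone rather than to several differences at once. Nothing measured here explains why the number moved.

The change also does two things together, removing the hetero atom of the aromatic ring and adding a fluorine, and the compounds shown cannot separate these two parts. Plain phenyl at this position would help to tell them apart, while a morpholine or a carboxylic acid on the ring would test how far the trend extends in this assay.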